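The source may report more compounds than this note shows. Statements on the series, on what has been measured and on what is new or still open speak of the compounds shown alone.

Series notes. Compound 2 `NC(=O)CC[C@H](NC(=O)CN(c1ncnc2c1ncn2C1CCCCO1)C1CC1)C(=O)OCc1ccccc1` gives 47% in a functional assay on the whole organism (Tail, strain ICR) with Mus musculus as the target, in the tail flick test, with a stated time of 30 min, at a dose of 25 umol/kg by the oral route (on this read-out lower numbers stand for a weaker effect and higher numbers for a stronger effect at the one dose given), the highest of the three numbers to hand. Compound 1 `CC[C@H](C)[C@H](NC(=O)CN(c1nc(Cl)nc2[nH]cnc12)C1CC1)C(=O)OCc1ccccc1` gives 41.4% in this assay, lower by an amount within the scatter, so no order between compound 1 and compound 2 is claimed. Compound 3 `NC(=O)CC[C@H](NC(=O)CN(c1nc(Cl)nc2[nH]cnc12)C1CC1)C(=O)O` gives 33.1% in this assay, lower than compound 2 by more than the scatter. Compound 4 `O=C(CN(c1ncnc2c1ncn2C1CCCCO1)C1CC1)N[C@@H](CC(=O)OCc1ccccc1)C(=O)OCc1ccccc1` is not yet measured and differs from compound 2 by benzyloxycarbonyl in place of carbamoylmethyl on a saturated chain carbon, two bonds along the chain from an amide-type nitrogen and a carbonyl carbon. Among the measured compounds shown here, no step between measured compounds differing in one place exists, so the change has no direct precedent. Compound 1 and compound 2 both carry a benzyloxycarbonyl and sit within the scatter of each other, and compound 4 keeps that group, so a step no larger than the scatter is expected, namely a number 5 percentage points lower from compound 2 to compound 4 (within the scatter). Compound 4 is estimated at 42% in this assay, within 25% to 60%.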

Compound 4, a percentage reported as activity, at one dose (the size of the read-out at that dose, not a potency): 31.8%
For compound 4 the middle estimate is 10.2 percentage points above the measured one; measured number inside the range.
By their numbers in this assay, from the lowest: compounds 4, 3, 1 and 2 (each within the scatter of the next, the first and the last beyond it).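

In this assay, among the compounds shown here, carbamoylmethyl gives way to benzyloxycarbonyl on a saturated chain carbon, two bonds along the chain from an amide-type nitrogen and a carbonyl carbon, with a number 15.2 percentage points lower from compound 2 to compound 4 (beyond the scatter), the first single-place step. The number at this position therefore depends on the group carried there, and the benzyloxycarbonyl shared by compound 2 and compound 4 does not keep it level. No measurement at hand accounts for the step.

As far as these compounds go, whether a carboxylic acid or a primary amine here would lower the number likewise remains open. So does the effect of a longer chain carrying the benzyloxycarbonyl.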